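A Pyridine Ring Enters Where a Methoxymethyl Group Left

The source may report more compounds than this note shows. Statements on the series, on what has been measured and on what is new or still open speak of the compounds shown alone.

This study looks at a small set of compounds sharing one core, all tested in an ADME assay on MRC5 cells (Homo sapiens) for inhibition, with a stated time of 72 h; on this read-out lower numbers stand for an effect already at smaller amounts and higher numbers for an effect only at larger amounts of compound. Compound 1 `CO[C@H]1CC[C@H](NC(=O)c2n[nH]cc2NC(=O)c2ccc(F)cc2F)CC1` gives 11000 nM in this assay. Compound 3 `COc1cccc(OC)c1C(=O)Nc1c[nH]nc1C(=O)NC1CCN(Cc2ccccc2)C1` gives 38000 nM in this assay. For compound 2 `COCCNC(=O)c1n[nH]cc1NC(=O)c1c(OC)cccc1OC` this assay reports only a limit, > 50000 nM, and no number. This is the limit of > 50000 nM in this assay, at which 1 of the 3 values shown sits, and compound 2 is the one that sits there. No two of the measured compounds differ in only one place, so the two numbers and the limit stand on their own, without a measured step between them.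

Compound 4 `COc1cccc(OC)c1C(=O)Nc1c[nH]nc1C(=O)NCc1ccccn1` has not yet been measured. It differs from compound 2 in a single spot: pyridin-2-yl in place of methoxymethyl on a saturated chain carbon bound to an amide-type nitrogen. The shared core stays intact, and only the group on the saturated chain carbon changes.

Since compound 2 gives only a limit, the size of the step to compound 4 cannot be read from the data and is an expectation only. The step expected from compound 2 to compound 4 is an at least 1.4-fold lower number from compound 2 to compound 4 (0.15 log units; that floor lies within the scatter), toward a somewhat smaller number, though it may well stay within the usual scatter or at the limit again. Compound 4 is estimated at 35000 nM, with a range from 12000 nM to 50000 nM.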

Compound 4, half-maximal effective concentration: > 50000 nM
Compound 4: only a limit was reported (the forecaster's own chance of this, stated with the estimate: 40%); middle value at least 1.4-fold (0.15 log units) away from the limit.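

Compound 2 and compound 4 both stop at a limit rather than a number, so no step between them can be read: the limit of > 50000 nM in this assay, at which 2 of the 4 values shown sit.

The compounds shown leave open whether pyridin-2-yl in place of methoxymethyl on a saturated chain carbon bound to an amide-type nitrogen shifts the read-out in this assay at all, and in which direction.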